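The source may report more compounds than this note shows. Statements on the series, on what has been measured and on what is new or still open speak of the compounds shown alone.

Measured compounds:
- compound 1, `CC(O)Cn1c([N+](=O)[O-])cnc1/C=C/c1ccc(F)cc1`, with 420 nM
- compound 2, `CC(O)Cn1c([N+](=O)[O-])cnc1/C=C/c1ccc(N(C)C)cc1`, with 680 nM

In an ADME assay on cells (Macrophage, Homo sapiens) for cytotoxicity, read by MTT assay, with a stated time of 24 h (a higher number here means that more compound is tolerated, a lower number that less compound is tolerated), compound 1 gives 420 nM, the lower of the two numbers, while compound 2 gives 680 nM. The step of a 1.6-fold higher number from compound 1 to compound 2 (0.21 log units; within the scatter) is within the scatter, so the two compounds cannot be told apart on these data.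

Compound 3, `CC(O)Cn1c([N+](=O)[O-])cnc1/C=C/c1ccccc1Br`, differs from compound 1 by 2-bromophenyl in place of 4-fluorophenyl on a double-bonded chain carbon bound to a double-bonded chain carbon. For the measured compounds named here, the only measured step that bears on this is the one from compound 1 to compound 2, which also exchanges the aromatic ring on the double-bonded chain carbon and which stayed within the scatter. No step beyond the scatter is therefore expected in this assay for compound 3. Compound 3 is estimated to give about 450 nM, with a range from 200 nM to 1000 nM. The expected step of a 1.1-fold higher number from compound 1 to compound 3 (0.03 log units; within the scatter) thus lies within the scatter.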

Compound 3, half-maximal cytotoxic concentration: 490 nM
Beside the measured number, compound 3's estimate is 1.1-fold (0.04 log units) below it; measured number inside the range.
By their numbers in this assay, from the lowest: compounds 1, 3 and 2 (each within the scatter of the next).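

In this assay, 2-bromophenyl in place of 4-fluorophenyl on a double-bonded chain carbon bound to a double-bonded chain carbon gives a 1.2-fold higher number from compound 1 to compound 3 (0.07 log units; within the scatter), so the two compounds cannot be told apart on these data. Compound 3 adds a second exchange of the aromatic ring, one in which, as the names 2-bromophenyl and 4-fluorophenyl show, both the halogen and its numbered place differ, and this exchange also stays within the scatter. Nothing measured here gives a reason for this result.

Since the halogen and its numbered place differ together, the contribution of each remains unresolved. As far as these compounds go, it also remains open whether a carboxylic acid on the aromatic ring, or a longer chain in place of the double-bonded chain, would produce a step beyond the scatter.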